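Side-chain variation on a shared core: compound 4

A few compounds are considered here, and "the series" means these few. Any claim that something is new, unique, unknown or untested is made for them only; others in the source may bear on it.

Measured compounds, in an assay on isolated protein for displacement of a labelled ligand from Adrenergic receptor alpha-1 (Rattus norvegicus); a lower number here means a stronger inhibitor, a higher number a weaker inhibitor:
compound 1 `COCCNC(=O)C1CCN(c2nc(N)c3cc(OC)c(OC)cc3n2)CC1` gives 1.13 nM
compound 2 `CCN(CC)C(=O)C1CCCN(c2nc(N)c3cc(OC)c(OC)cc3n2)C1` gives 117 nM
compound 3 `COc1cc2nc(N3CCC(C(=O)NCCOc4ccccc4)CC3)nc(N)c2cc1OC` gives 0.42 nM

Compound 1 holds the second highest of the three numbers in this assay: compound 3 is nearest, compound 2 furthest. Compound 4 `CCCCNC(=O)COC1CCN(c2nc(N)c3cc(OC)c(OC)cc3n2)CC1` is not yet measured. Change from compound 1 to compound 4: (butylcarbamoyl)methoxy in place of (2-methoxyethyl)carbamoyl on a saturated ring carbon. Among the measured compounds shown here, the only step on a measured pair, a 2.7-fold lower number from compound 1 to compound 3 (0.43 log units; beyond the scatter), extends the same side chain at its far end and lowers the number; no step on this exact change exists. A step of similar or smaller size is therefore expected, direction uncertain, likely within scatter: a 1.6-fold higher number from compound 1 to compound 4 (0.20 log units; within the scatter). Compound 4 is estimated at 1.8 nM, range 0.5 nM to 7 nM.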

Compound 4, inhibition constant: 0.79 nM
Estimate against measurement, compound 4: 2.3-fold (0.36 log units) above; low and high end bracket the measured number.
By their numbers in this assay, from the lowest: compounds 3, 4 and 1 (each within the scatter of the next, the first and the last beyond it); then compound 2.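

In this assay, (butylcarbamoyl)methoxy in place of (2-methoxyethyl)carbamoyl on this saturated ring carbon gives a 1.4-fold lower number from compound 1 to compound 4 (0.16 log units; within the scatter), so the number holds when the side chain is attached through an oxygen rather than through its carbonyl. The attachment and the far end of the chain change together in this step, and it cannot separate the two. No measurement here explains why the number holds. Still open, from the compounds shown here alone, is whether an amine or a carboxylic acid at the far end of the oxygen-attached chain, or a longer chain, would keep the number.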